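This account rests on a few compounds, and the source may have more. Where it says the series, first, only, none or still open, it means among the compounds named here.

In a physicochemical assay for solubility, read by spectrophotometry (on this read-out higher numbers stand for higher solubility and lower numbers for lower solubility), two compounds have been read so far, compound 1 `O=C(Oc1ccc(Cl)cc1C(=O)Nc1ccc(Cl)c(Cl)c1)c1cnc(Cl)cn1` and compound 2 `O=C(NCCCCl)Oc1ccc(Cl)cc1C(=O)Nc1ccc(Cl)c(Cl)c1`. Compound 1 gives < 100000 nM, which is a limit and not a number. Compound 2 gives < 50000 nM, which is also a limit. Compound 2 therefore stands on a limit, with no number to build on. Among the measured compounds shown here, the only measured step, a step that the two limits leave unreadable from compound 1 to compound 2, has no readable size, and it concerns the group on a carbonyl carbon rather than the change at issue here.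

Compound 3 `CCCNC(=O)Oc1ccc(Cl)cc1C(=O)Nc1ccc(Cl)c(Cl)c1` carries a single edit on the chain of compound 2: hydrogen in place of chloro on a saturated chain carbon, three bonds along the chain from an amide-type nitrogen. In words, this is hydrogen in place of chloro on a saturated chain carbon, three bonds along the chain from an amide-type nitrogen, so 3-chloropropyl becomes propyl. For the measured compounds named here, no measured step shows what this change does in this assay, so no shift beyond the usual scatter is expected and no direction is favoured. The expected size is a step that the limit leaves unreadable from compound 2 to compound 3. For compound 3 the estimated value is 30000 nM. The estimated range for compound 3 runs from 8000 nM to 60000 nM, and another limit would be no surprise.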

Compound 3, solubility: < 50000 nM
Compound 3 gave a limit, no number (the forecaster's own chance of this, stated with the estimate: 65%); the middle value is on the limit's open side.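

In this assay compound 3 gives < 50000 nM and this is a limit, not a number. Among the compounds shown here, no step linking compound 3 with compound 2 or compound 1 can be read. The compounds shown leave open where the solubility of any of the three actually lies, and whether 3-chloropropyl to propyl changes it at all.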